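Replacing 4-fluorophenyl with 3,4-dimethoxyphenyl on a weak growth inhibitor

This account rests on a few compounds, and the source may have more. Where it says the series, first, only, none or still open, it means among the compounds named here.

Three compounds have been measured in a functional assay on PC-3 cells (Homo sapiens) for inhibition, read by sulforhodamine B assay; on this read-out lower numbers stand for stronger inhibition of growth and higher numbers for weaker inhibition of growth:

Compound 1 `Cc1ccc2[nH]c(-c3ccc(-c4ccc(-c5ccc(N(C)C)cc5)cc4)cc3)nc2c1`: 8120 nM
Compound 2 `COc1cc(-c2ccc(-c3ccc(-c4nc5cc(C)ccc5[nH]4)cc3)cc2)cc(OC)c1OC`: 180 nM
Compound 3 `Fc1ccc(-c2ccc(-c3ccc(-c4nc5ccccc5[nH]4)cc3)cc2)cc1`: 41200 nM

Of these three, compound 3 has the highest number, 41200 nM, and so shows the weakest inhibition of growth. Compound 1 lies closest to it at 8120 nM, while compound 2 lies furthest away at 180 nM.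

The next compound is compound 4 `COc1ccc(-c2ccc(-c3ccc(-c4nc5ccccc5[nH]4)cc3)cc2)cc1OC`, which has 3,4-dimethoxyphenyl in place of 4-fluorophenyl on an aromatic carbon, para to a large group: 3,4-dimethoxyphenyl in place of 4-fluorophenyl on an aromatic carbon. The shared core of compound 3 is otherwise kept.

Among the measured compounds shown here, no measured pair differs in only one place, so the size of this change has not been observed directly. The best available guide is compound 2, which also carries methoxy groups and gives 180 nM. However, it differs from compound 3 in more than one place, so only part of that gap can be expected to carry over. In this assay the expected step is a 16-fold lower number from compound 3 to compound 4 (1.22 log units; beyond the scatter), toward stronger inhibition of growth and beyond the scatter. For compound 4 the estimated value is 2500 nM, with an expected range from 300 nM to 15000 nM.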

Compound 4, concentration for 50% growth inhibition: 47100 nM
Beside the measured number, compound 4's estimate is 19-fold (1.28 log units) below it; measured number above the stated range.
By their numbers in this assay, from the lowest: compound 2; then compound 1; then compounds 3 and 4 (each within the scatter of the next).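

In this assay, among the compounds shown here, putting 3,4-dimethoxyphenyl in place of 4-fluorophenyl on an aromatic carbon, para to a large group, gives a 1.1-fold higher number from compound 3 to compound 4 (0.06 log units; within the scatter), the only step at this position that can be read directly. On the shared core of compound 3, then, this exchange leaves compound 3 and compound 4 indistinguishable by this read-out, even though the entering group brings hydrogen-bond acceptors that the leaving group lacks, so methoxy groups at this place are not sufficient in themselves to give a low number on this core. Nothing measured here indicates why the two groups read alike.

What remains open is what accounts for the low number of compound 2, 180 nM, since its additional methoxy group and the methyl on its core are not separated by any pair that differs in one place. On these data alone, it is also open whether a carboxylic acid or a primary amine at this same position would move the number away from that of compound 3, 41200 nM, in either direction.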